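A few compounds are considered here, and "the series" means these few. Any claim that something is new, unique, unknown or untested is made for them only; others in the source may bear on it.

Of the compounds shown here, two have been tested so far, both built on the same shared core with a varied chain on the amide. Compound 1 `O=C(CCCc1ccccc1)Nc1nc2ccccc2c(=O)s1` carries a saturated chain on that amide. In an assay on CHO cells for displacement of a labelled ligand from adenosine receptor A3 (Homo sapiens), read by scintillation counting, with a stated time of 60 min (a lower number here means a stronger inhibitor, a higher number a weaker inhibitor), compound 1 gives only a limit, > 1000 nM, and no number. Compound 2 `COc1cccc(/C=C/CC(=O)Nc2nc3ccccc3c(=O)s2)c1` carries an unsaturated chain ending in a 3-methoxyphenyl group, and in this assay compound 2 gives 115 nM. Among the values shown, this is the only number in this assay; the other value sits at the limit (the limit of > 1000 nM in this assay, at which 1 of the 2 values shown sits).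

Compound 3 `O=C(C/C=C/c1cccc(Cl)c1)Nc1nc2ccccc2c(=O)s1` has not yet been measured. It differs from compound 2 in one place: chloro in place of methoxy on an aromatic carbon. Going by the values given here, no measured pair shows a step of this kind, so its size cannot be read from the data. The expectation is a shift no larger than the scatter, in either direction, and the estimated step is a 1.3-fold higher number from compound 2 to compound 3 (0.12 log units; within the scatter). Compound 3 is therefore expected to give about 150 nM in this assay, with an estimated range from 50 nM to 450 nM.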

Compound 3, inhibition constant: > 1000 nM
Compound 3 was reported as a limit (the forecaster's own chance of this, stated with the estimate: 10%); middle value at least 6.6-fold (0.82 log units) from the limit.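

Going by these compounds alone, the change from 3-methoxyphenyl to 3-chlorophenyl is the first single-place step, and in this assay it gives an at least 8.6-fold higher number from compound 2 to compound 3 (0.93 log units; beyond the scatter). From the compounds shown here alone, compound 3 gives > 1000 nM, which is a limit of the assay and not a number, so the step has a lower bound only and its full size remains unknown. With the unsaturated chain held fixed, this aromatic carbon is therefore not indifferent to the group it carries, and compound 2 remains the only compound with a number, the others sitting at one limit: the limit of > 1000 nM in this assay, at which 2 of the 3 values shown sit.

Still open, going by these compounds, is whether a number in this assay is kept by other groups at this place, such as hydroxy, ethoxy, fluoro, methyl or an amine, so one methoxy-to-chloro pair cannot yet show whether methoxy is specifically required. Also open, on these data alone, is whether a saturated chain ending in 3-methoxyphenyl gives a number, which would separate the contribution of the chain from that of the methoxy group.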